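The source may hold more compounds than are shown below. What is called first, only, known or untested is meant among the compounds shown, and "the series" means these compounds.

Compound 1 `FC(F)(F)c1ccc(CN2CCN(Cc3cc(-c4ccc(OCc5cccc(Cl)c5)cc4)on3)CC2)cc1`: 4100 nM
Compound 2 `FC(F)(F)c1ccc(CN2CCN(Cc3cc(-c4ccc(OCc5ccc(Cl)cc5)cc4)on3)CC2)cc1`: 3700 nM
Compound 3 `Fc1cccc(COc2ccc(-c3cc(CN4CCN(Cc5ccc(C(F)(F)F)cc5)CC4)no3)cc2)c1`: 2900 nM

In a functional assay on Mahlavu cells (Homo sapiens) for antiproliferative activity, read by sulforhodamine B assay, with a stated time of 72 h (a higher number here means a weaker inhibitor, a lower number a stronger inhibitor), compound 2 stands second highest of the three numbers, with compound 1 nearest and compound 3 furthest, yet both gaps lie within the scatter. Compound 4 `COc1cccc(COc2ccc(-c3cc(CN4CCN(Cc5ccc(C(F)(F)F)cc5)CC4)no3)cc2)c1` differs from compound 2 in one place: 3-methoxyphenyl in place of 4-chlorophenyl on a saturated chain carbon bound to an oxygen on an aromatic ring. All three measured steps alter this same benzyl group and stay within the scatter: a 1.1-fold lower number from compound 1 to compound 2 (0.04 log units; within the scatter), a 1.3-fold lower number from compound 2 to compound 3 (0.11 log units; within the scatter), a 1.4-fold lower number from compound 1 to compound 3 (0.15 log units; within the scatter). Swapping one halogenated phenyl for another thus left the read-out essentially unchanged; whether a methoxy group behaves the same is untested, so no step beyond the scatter is expected, in either direction. The expected step is a 1.1-fold lower number from compound 2 to compound 4 (0.02 log units; within the scatter). Compound 4 is therefore estimated at 3500 nM, within a range of 1500 nM to 8000 nM.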

Compound 4, half-maximal inhibitory concentration: 1400 nM
Compound 4: the middle estimate sits 2.5-fold (0.40 log units) above what was measured; the whole stated range lies above it.
By their numbers in this assay, from the lowest: compound 4; then compounds 3, 2 and 1 (each within the scatter of the next).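

In this assay this position proves sensitive to the group it carries: 3-methoxyphenyl in place of 4-chlorophenyl gives a 2.6-fold lower number from compound 2 to compound 4 (0.42 log units; beyond the scatter), beyond the scatter, unlike the swaps among halogenated phenyls. The change of ring position alone does not account for this, as methoxy in place of fluoro gives a 2.1-fold lower number from compound 3 to compound 4 (0.32 log units; beyond the scatter) and methoxy in place of chloro gives a 2.9-fold lower number from compound 1 to compound 4 (0.47 log units; beyond the scatter), both modest but beyond the scatter. No available evidence explains the shift. Going by these compounds, whether 4-methoxyphenyl would behave like 3-methoxyphenyl remains open. So does the outcome with an ethoxy, hydroxy or amino group on that ring.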